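Swapping an Acetoxymethyl Ester for an Amide on the Ring

The source may report more compounds than this note shows. Statements on the series, on what has been measured and on what is new or still open speak of the compounds shown alone.

Compound 1: `CC(=O)OC/C1=C/C[C@](C)(CCC=C(C)C)/C=C/[C@@H](OC(=O)C=C(C)C)[C@](C)(O)/C=C/C1=O`, 2950 nM
Compound 2: `CC(C)=CCC[C@]1(C)/C=C/[C@@H](OC(=O)C=C(C)C)[C@](C)(O)CCC(=O)/C(CO)=C\C1`, > 40000 nM
Compound 3: `CC(C)=CCC[C@](C)(/C=C/[C@@H](OC(=O)C=C(C)C)[C@](C)(O)/C=C/C(=O)/C=C/N(C)C)CC=O`, 10300 nM

These three compounds share a core and were tested in a functional assay on SW480 cells (Homo sapiens) for antiproliferative activity, read by MTT assay, with a stated time of 48 h; a lower number here means a stronger inhibitor, a higher number a weaker inhibitor. Compound 1 has the lower of the two numbers reported, while compound 3 sits at a higher number, a gap beyond the usual scatter. Compound 2 gave no number in this assay, only a limit, (the limit of > 40000 nM in this assay, at which 1 of the 3 values shown sits). Compound 4, `CC(C)=CCC[C@]1(C)/C=C/[C@@H](OC(=O)C=C(C)C)[C@](C)(O)/C=C/C(=O)/C(C(=O)N(C)C)=C\C1`, is not yet measured. It differs from compound 1 in a single place: dimethylcarbamoyl in place of acetoxymethyl on a double-bonded ring carbon. Among the measured compounds shown here, no measured pair shows the effect of this particular swap, and the step is estimated as a modest weakening, a 1.7-fold higher number from compound 1 to compound 4 (0.23 log units; within the scatter). Compound 4 is therefore expected to give about 5000 nM, with a likely range from 1500 nM to 20000 nM.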

Compound 4, half-maximal inhibitory concentration: 3300 nM
Compound 4: the middle estimate sits 1.5-fold (0.18 log units) above what was measured; low and high end bracket the measured number.
By their numbers in this assay, from the lowest: compounds 1 and 4 (each within the scatter of the next); then compound 3. At a limit, above all of these: compound 2.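

In this assay the swap gives a 1.1-fold higher number from compound 1 to compound 4 (0.05 log units; within the scatter) and so shows that this double-bonded ring carbon can carry dimethylcarbamoyl in place of acetoxymethyl with no change beyond the scatter. An ester is therefore not required at this position for the activity seen here, at least when replaced by this amide. Nothing measured here explains why the two groups read alike. Still open, from the compounds shown here alone, is whether a carboxylic acid, an amine or a longer chain on this carbon would read the same.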